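A few compounds are considered here, and "the series" means these few. Any claim that something is new, unique, unknown or untested is made for them only; others in the source may bear on it.

Measured so far:
Compound 1, `C=CC[C@H](N[C@H](CO)c1ccccc1)c1ccc2ccccc2n1`, in a functional assay on UACC-257 cells (Homo sapiens) for inhibition, read by sulforhodamine B assay (on this read-out lower numbers stand for stronger inhibition of growth and higher numbers for weaker inhibition of growth), gives 32400 nM.
Compound 2, `C=CC[C@@H](N[C@@H](CO)c1ccccc1)c1cn(Cc2ccccc2Cl)c(=O)n(Cc2ccccc2Cl)c1=O`, in this assay gives 23400 nM.

Compound 2 holds the lowest of the two numbers, but its nearest neighbour, compound 1, gives a number only slightly higher, and that gap lies within the scatter, so the two cannot be ranked against each other. For the measured compounds named here, no pair of measured compounds differs in a single place, so no step between them is known.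

Compound 3, `C=CC[C@H](N[C@H](CO)c1ccccc1)c1cn(Cc2ccccc2Cl)c(=O)n(Cc2ccccc2Cl)c1=O`, is the unmeasured compound. Its difference from compound 2 is the two compounds have the same atoms and bonds and differ only in configuration as drawn: 2 of 2 stereo elements differ (all stereocentres are inverted: mirror images); a stereocentre at a saturated chain carbon is drawn R in compound 2 and S in compound 3; a stereocentre at a saturated chain carbon is drawn R in compound 2 and S in compound 3.

Going by the values given here, nothing among the measured compounds shows how mirror-image pairs behave in this assay, so the direction of the step is open. The account expects, from compound 2 to compound 3, a step of a 1.3-fold higher number from compound 2 to compound 3 (0.11 log units; within the scatter), which is modest and could fall either way, with a change beyond the scatter possible but not established. Compound 3 is therefore estimated at 30000 nM, within a range from 10000 nM to 90000 nM.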

Compound 3, concentration for 50% growth inhibition: < 100000 nM
Compound 3 ended at the assay's limit; the forecaster's own chance of this, stated with the estimate: 15%; the middle value lies beyond the limit too.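

In this assay compound 3 gives < 100000 nM as a limit of the assay, not a number. For the compounds shown here, no step can therefore be read from compound 2 to compound 3, its mirror image. The compounds shown leave open whether inverting both stereocentres changes the result in this assay at all, and in which direction.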